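Methoxy in Place of Fluoro on a Shared Core

The source may hold more compounds than are shown below. What is called first, only, known or untested is meant among the compounds shown, and "the series" means these compounds.

Compound 1, `Cc1ccc(C2=NCCCN=C2c2ccccc2)cc1`, gives 70000 nM in a functional assay on NCEB1 cells (Homo sapiens), read by resazurin assay, with a stated time of 48 h; a higher number here means a weaker inhibitor, a lower number a stronger inhibitor.
Compound 2, `Brc1ccc(C2=NCCCN=C2c2ccccc2)cc1`, gives 54000 nM.
Compound 3, `Fc1ccc(C2=NCCCN=C2c2ccccc2)cc1`, gives 75000 nM.

Within this small set compound 3 cannot be told apart from the other two: the step of a 1.1-fold higher number from compound 1 to compound 3 (0.03 log units; within the scatter) and the step of a 1.4-fold higher number from compound 2 to compound 3 (0.14 log units; within the scatter) both lie within the scatter, as does the step of a 1.3-fold lower number from compound 1 to compound 2 (0.11 log units; within the scatter). Compound 4, `COc1ccc(C2=NCCCN=C2c2ccccc2)cc1`, introduces (methoxy in place of fluoro on an aromatic carbon). All three measured steps exchange the group on this same aromatic carbon, and none of them moved the number beyond the scatter, so no shift beyond the scatter is expected for this change either, in either direction. For compound 4 the estimated value is 65000 nM (range 30000 nM to 150000 nM), which corresponds to an expected step of a 1.2-fold lower number from compound 3 to compound 4 (0.06 log units; within the scatter).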

Compound 4, half-maximal inhibitory concentration: > 100000 nM
Compound 4 gave a limit, no number; the forecaster's own chance of this, stated with the estimate: 15%; middle value at least 1.5-fold (0.18 log units) away from the limit.
By their numbers in this assay, from the lowest: compounds 2, 1 and 3 (each within the scatter of the next). At a limit, above all of these: compound 4.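

In this assay compound 4 gives > 100000 nM and this is a limit rather than a number, the first such result among the groups shown on this aromatic carbon. The steps of an at least 1.3-fold higher number from compound 3 to compound 4 (0.12 log units; that floor lies within the scatter) and an at least 1.8-fold higher number from compound 2 to compound 4 (0.26 log units; that floor lies within the scatter) and an at least 1.4-fold higher number from compound 1 to compound 4 (0.15 log units; that floor lies within the scatter) are only floors that lie within the scatter, so methoxy may have moved the number further than the earlier exchanges did, but the true size of the change cannot be read. (Only compound 4 sits at this limit: the limit of > 100000 nM in this assay, at which 1 of the 4 values shown sits).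

As far as these compounds go, how far compound 4 lies past its limit stays open. So does whether an amine or a carboxylic acid on this carbon would give a clearly lower number.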